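The compounds below may be only part of what the source reports. "The series", "measured", "known", "first", "only" and "open" are said of these compounds alone.

Measured compounds in an ADME assay on MDBK cells (Bos taurus) for cytotoxicity, read by MTT assay, with a stated time of 96 h; on this read-out lower numbers stand for higher toxicity in this test and higher numbers for lower toxicity in this test:
compound 1, `CC(=O)Nc1ccc(-c2nc3cc(C(F)(F)F)ccc3[nH]2)cc1`, 50000 nM
compound 2, `O=C(CN1CCCC1)Nc1ccc(-c2nc3cc(C(F)(F)F)ccc3[nH]2)cc1`, 15000 nM

In this assay, within the data shown here, compound 2 stands lowest of the two numbers; its only neighbour is compound 1, which sits higher by a 3.3-fold lower number from compound 1 to compound 2 (0.52 log units; beyond the scatter), a step beyond the scatter. Among the measured compounds shown here, that addition of pyrrolidin-1-yl on a saturated chain carbon bound to a carbonyl carbon is the one measured change.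

Compound 3, `O=C(CN1CCCCC1)Nc1ccc(-c2nc3cc(C(F)(F)F)ccc3[nH]2)cc1`, differs from compound 2 by piperidin-1-yl in place of pyrrolidin-1-yl on a saturated chain carbon bound to a carbonyl carbon. For the measured compounds named here, no measured step exchanges a five-membered ring for a six-membered one at this place, so this change is not covered by the data. The only bearing observation is that compound 2 already carries pyrrolidin-1-yl and gives 15000 nM, and compound 3 keeps a ring of the same kind there. The expected step is therefore a 1.3-fold lower number from compound 2 to compound 3 (0.10 log units; within the scatter), within the scatter, with a slight lean toward a lower number. Compound 3 is estimated at 12000 nM, with a range of 5000 nM to 30000 nM.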

Compound 3, half-maximal cytotoxic concentration: 6000 nM
For compound 3 the middle estimate is 2.0-fold (0.30 log units) above the measured one, within the range that was stated.
By their numbers in this assay, from the lowest: compound 3; then compound 2; then compound 1.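

Among these compounds, the earlier compounds showed only that adding a ring on the saturated chain carbon bound to a carbonyl carbon moved the number in this assay; the ring itself now matters, with piperidin-1-yl in place of pyrrolidin-1-yl giving a 2.5-fold lower number from compound 2 to compound 3 (0.40 log units; beyond the scatter), a step beyond the scatter. Set against the hydrogen of compound 1, piperidin-1-yl gives an 8.3-fold lower number from compound 1 to compound 3 (0.92 log units; beyond the scatter), so both ring-bearing compounds lie below compound 1 and the six-membered ring lies lowest of the three. Nothing available accounts for the difference between the two rings.

From the compounds shown here alone, whether the number keeps falling with ring size stays open, and a seven-membered azepane or a morpholine at this place would bear on that. Also open, going by these compounds, is how an open-chain dimethylamino group, or a longer chain carrying the piperidin-1-yl group, would compare.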